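The source may hold more compounds than are shown below. What is called first, only, known or untested is meant among the compounds shown, and "the series" means these compounds.

For the measured compounds named here, compound 3 `CC(C)c1cccc(NC(=O)CCc2cccc3c2B(O)OC3)c1` gives 22000 nM in an ADME assay on WI-38 cells (Homo sapiens) for cytotoxicity, read by MTT assay, with a stated time of 72 h (a lower number here means a stronger inhibitor, a higher number a weaker inhibitor), the only number among the three measured compounds. Compound 1 `Cc1ccc(NC(=O)CCc2cccc3c2B(O)OC3)cc1` gives > 100000 nM in this assay, which is a limit and not a number. Compound 2 `COc1ccc(NC(=O)CCc2cccc3c2B(O)OC3)cc1` gives > 100000 nM, again a limit. Going by the values given here, the one measured step, a step that the two limits leave unreadable from compound 1 to compound 2, cannot be sized because both of its values sit at the limit of > 100000 nM in this assay, at which 2 of the 3 values shown sit. Compound 4 `CSc1cccc(-c2cccc(NC(=O)CCc3cccc4c3B(O)OC4)c2)c1` differs from compound 3 by 3-(methylsulfanyl)phenyl in place of isopropyl on an aromatic carbon. Among the compounds with values here, no measured step bears on this change, so nothing in the data points to a shift beyond the scatter in this assay. Compound 4 is therefore expected to give about 20000 nM, between 5000 nM and 100000 nM. The implied step a 1.1-fold lower number from compound 3 to compound 4 (0.04 log units; within the scatter) is estimated to stay within the scatter.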

Compound 4, half-maximal inhibitory concentration: 2000 nM
Beside the measured number, compound 4's estimate is 10-fold (1.00 log units) above it; the whole stated range lies above it.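

In this assay, 3-(methylsulfanyl)phenyl in place of isopropyl on this aromatic carbon gives an 11-fold lower number from compound 3 to compound 4 (1.04 log units; beyond the scatter), so this position can respond strongly to a change of group. For the compounds shown here, compound 3 and compound 4 form the only pair here with a readable step, and the larger group with its added aromatic ring goes with the lower number. The other compounds offer no such reading: the limit of > 100000 nM in this assay, at which 2 of the 4 values shown sit.

From the compounds shown here alone, whether plain phenyl would give the same lower number remains open. So does the outcome with an amine or a carboxylic acid in place of methylsulfanyl.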